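This account rests on a few compounds, and the source may have more. Where it says the series, first, only, none or still open, it means among the compounds named here.

Among the two compounds already measured, compound 2 `CCOC(=O)C1=C(C)NC(C)=C(C(=O)OCC)C1c1ccc(OCC(=O)NNC(=O)c2sccc2Cl)cc1` stands lowest: in a functional assay on the whole organism (strain Wistar) for inhibition, with Rattus norvegicus as the target, read by paw edema, with stated times of 30 min and 1 h, at a dose of 20 mg/kg (a lower number here means less inhibition, a higher number more inhibition at the dose given (going by the name of the read-out)), compound 2 gives 39.7%. For the measured compounds named here, its only neighbour, compound 1 `CCOC(=O)C1=C(C)NC(C)=C(C(=O)OCC)C1c1ccc(OCC(=O)Nc2ccc(C)cc2)cc1`, gives 55.1% in this assay, and the step of a number 15.4 percentage points lower from compound 1 to compound 2 (beyond the scatter) came with a different group on the amide-type nitrogen. Compound 3 `CCOC(=O)C1=C(C)NC(C)=C(C(=O)OCC)C1c1ccc(OCC(=O)NNC(=O)c2cccs2)cc1` keeps the whole of compound 2 apart from one point: hydrogen in place of chloro on an aromatic carbon, that is, the 3-chlorothiophen-2-yl group becomes thiophen-2-yl. Going by the values given here, no measured step removes a chloro from a ring; the single step on record swaps an entire amide substituent and therefore bears on this change only loosely. The reasonable expectation is a step in this assay no larger than the scatter, in either direction, so for compound 3 the estimated value is 40%, within 25% to 55%. Put as a step, the estimate for compound 3 means a number 0.3 percentage points higher from compound 2 to compound 3 (within the scatter), expected to stay within the scatter.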

Compound 3, a percentage reported as inhibition, in the whole organism at one dose (the size of the read-out at that dose, not a potency): 55.1%
Compound 3: middle estimate off by 15.1 percentage points, on the low side, and the stated range ends below it.
By their numbers in this assay, from the lowest: compound 2; then compounds 1 and 3 (each within the scatter of the next).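

In this assay, taking the single chloro off the thiophene ring gives a number 15.4 percentage points higher from compound 2 to compound 3 (beyond the scatter), so this one atom, on the ring carbon next to the ring atom that bears a large group, makes a difference beyond the scatter. The other new comparison reads no change at the digits printed from compound 1 to compound 3 (within the scatter) and shows that a ((thiophen-2-yl)carbonyl)amino group can take the place of 4-methylphenyl with no visible loss, so the lower number of compound 2 goes with the chloro and not with that longer substituent as such. Nothing measured here explains why the chloro has this effect.

As far as these compounds go, it remains open whether a fluoro, a bromo or a methyl at this ring carbon would behave like the chloro or like hydrogen. Also open, from the compounds shown here alone, is whether a chloro on another carbon of the thiophene ring would matter in the same way.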